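The source may hold more compounds than are shown below. What is called first, only, known or untested is meant among the compounds shown, and "the series" means these compounds.

Of the compounds shown here, three built on one shared core have been tested in an ADME assay on Vero cells (Chlorocebus sabaeus) for cytotoxicity; a lower number here means that less compound is tolerated, a higher number that more compound is tolerated. Compound 1 (`CC(=O)c1c(Nc2ccc(F)cc2F)[nH]c2c(F)cc(F)cc2c1=O`) gives > 25000 nM, which is a limit and not a number. Compound 2 (`COc1ccc(CNc2[nH]c3c(F)cc(F)cc3c(=O)c2C(C)=O)cc1`) gives > 25000 nM, again a limit. Compound 3 (`CC(=O)c1c(Nc2ccc(F)c(F)c2F)[nH]c2c(F)cc(F)cc2c1=O`) gives > 25000 nM, also a limit. Compound 3 therefore stands with the other two, and the whole picture so far is the limit of > 25000 nM in this assay, at which 3 of the 3 values shown sit.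

The next compound, compound 4 (`CC(C)C(=O)c1c(Nc2ccc(F)c(F)c2F)[nH]c2c(F)cc(F)cc2c1=O`), carries isopropyl in place of methyl on a carbonyl carbon. The only measured step among these compounds is a step that the two limits leave unreadable from compound 1 to compound 3, where a fluoro takes the place of a hydrogen on an aromatic carbon. For the measured compounds named here, that step involves a different change and has no readable size, and no measured step alters the group on the carbonyl carbon. No step beyond the usual scatter is therefore expected in this assay, in either direction. This expectation rests on compound 3 and the two others, which share one result: the limit of > 25000 nM in this assay, at which 3 of the 3 values shown sit. The estimated step is a step that the limit leaves unreadable from compound 3 to compound 4. Compound 4 is expected near 30000 nM, with an estimated range from 15000 nM to 60000 nM, and the assay will most likely report only a limit again.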

Compound 4, half-maximal cytotoxic concentration: > 25000 nM
Compound 4: a limit, no number (the forecaster's own chance of this, stated with the estimate: 85%); the middle value lies beyond the limit too.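

Compound 4 gives > 25000 nM in this assay, which is a limit and not a number. Compound 3 sits at the same limit, so no size can be read for the change from compound 3 to compound 4. The compounds shown leave open how far each true half-maximal cytotoxic concentration lies past that limit, and whether any of these changes matters in this assay.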